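The source may hold more compounds than are shown below. What is called first, only, known or untested is meant among the compounds shown, and "the series" means these compounds.

Compound 1 `COc1ccc(/C=C/C(=O)c2ccc(OCC3CO3)cc2)cc1` and compound 2 `COc1ccc(C(=O)/C=C/c2ccc(OCC3CO3)cc2)cc1` are built from the same atoms joined differently; the difference between the two cores is not broken down here. In a functional assay on MCF7 cells (Homo sapiens) for cytotoxicity, read by MTT assay (a higher number here means a weaker inhibitor, a lower number a stronger inhibitor), compound 1 gives 11600 nM. In this assay compound 2 gives 10900 nM. These two numbers lie within the usual scatter of each other, so nothing can be said about which of the two is the stronger.

Compound 3 `COc1ccc(C(=O)/C=C/c2ccc(OCC(O)CCl)cc2)cc1` differs from compound 2 in one place, namely (2-chloro-1-hydroxyethyl in place of oxiran-2-yl on a saturated chain carbon bound to an oxygen on an aromatic ring). In this assay compound 3 gives 29200 nM. The step of a 2.7-fold higher number from compound 2 to compound 3 (0.43 log units; beyond the scatter).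

Compound 4 `COc1ccc(/C=C/C(=O)c2ccc(OCC(O)CCl)cc2)cc1` has not yet been measured in this assay. It differs from compound 1 by 2-chloro-1-hydroxyethyl in place of oxiran-2-yl on a saturated chain carbon bound to an oxygen on an aromatic ring. This is the same change that was made between compound 2 and compound 3, at the same place, and no other pair among the compounds shown carries it. Within the data shown here, because compound 1 gives 11600 nM, and because the only measured example of this change is a 2.7-fold higher number from compound 2 to compound 3 (0.43 log units; beyond the scatter), the step from compound 1 to compound 4 is expected to be of a similar, modest size: a 2.6-fold higher number from compound 1 to compound 4 (0.41 log units; beyond the scatter) is the estimate. The expectation rests on a single measured pair, so it is held loosely. For compound 4 in this assay the estimated value is 30000 nM, expected to fall between 14000 nM and 65000 nM.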

Compound 4, half-maximal inhibitory concentration: 18500 nM
Compound 4: the middle estimate sits 1.6-fold (0.21 log units) above what was measured; low and high end bracket the measured number.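

On the core of compound 1, putting 2-chloro-1-hydroxyethyl in place of oxiran-2-yl gives, in this assay, a 1.6-fold higher number from compound 1 to compound 4 (0.20 log units; within the scatter), so this step alone does not separate the two compounds. Set beside the earlier step, it can be read as the same change behaving alike on the two cores, since the gap between the two steps does not exceed what two such steps would show by scatter alone: the same change on two cores in this assay, a 2.7-fold higher number (0.43 log units; beyond the scatter) from compound 2 to compound 3 and a 1.6-fold higher number (0.20 log units; within the scatter) from compound 1 to compound 4, 1.7-fold (0.23 log units) apart, within the scatter of two such steps

Among these compounds, this agreement does not show that the change has one fixed size, as only one of the two steps lies beyond the scatter, and two pairs say nothing about any further core or about why the numbers fall as they do.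

The compounds shown leave open how the series would respond to other groups at this place on the saturated chain carbon bound to an oxygen on an aromatic ring, such as an amine, a carboxylic acid or a longer chain in place of oxiran-2-yl. They also leave open whether the same exchange would hold on a core carrying something other than the methoxy group, for instance a halogen or an ethoxy group.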